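Fluoro to hydrogen on the chloro sulfonamide

This account rests on a few compounds, and the source may have more. Where it says the series, first, only, none or still open, it means among the compounds named here.

Values in a functional assay on HepG2 cells (Homo sapiens) for antiproliferative activity, read by MTT assay, with a stated time of 72 h (a higher number here means a weaker inhibitor, a lower number a stronger inhibitor), so far
compound 1 `COc1ncc(-c2ccc3c(c2)N(c2ccc(F)cc2)C(=O)CO3)cc1NS(=O)(=O)c1ccc(F)cc1` gives 36400 nM
compound 2 `O=C1COc2ccc(-c3cnc(Cl)c(NS(=O)(=O)c4ccc(F)cc4)c3)cc2N1c1ccc(F)cc1` gives > 40000 nM as a limit
compound 3 `COc1ncc(-c2ccc3c(c2)N(C2CC2)C(=O)CO3)cc1NS(=O)(=O)c1ccc(F)cc1` gives 14400 nM

Compound 2 gives only a limit (> 40000 nM) and no number. Compound 2 thus stands at the limit of > 40000 nM in this assay, at which 1 of the 3 values shown sits, and offers no exact starting value. Compound 4 `O=C1COc2ccc(-c3cnc(Cl)c(NS(=O)(=O)c4ccc(F)cc4)c3)cc2N1c1ccccc1` differs from it by hydrogen in place of fluoro on an aromatic carbon (hydrogen in place of fluoro on an aromatic carbon, 4-fluorophenyl to phenyl) and is still to be measured.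

Going by the values given here, no measured step isolates this change. The closest is a 2.5-fold lower number from compound 1 to compound 3 (0.40 log units; beyond the scatter) for cyclopropyl in place of 4-fluorophenyl on an amide-type nitrogen in a ring, a modest step that replaces the whole group, so hydrogen in place of fluoro is expected to give no step beyond the scatter in this assay in either direction. The step of an at least 1.0-fold higher number from compound 1 to compound 2 (0.04 log units; that floor lies within the scatter) concerns chloro in place of methoxy, a change elsewhere in the structure that compound 4 shares with compound 2.

A limit reading for compound 4 is also expected to be quite possible. The expected step is an at least 1.0-fold lower number from compound 2 to compound 4 (0.02 log units; that floor lies within the scatter) and it is an estimate only. For compound 4 the expected value is 38000 nM (estimated range 20000 nM to 70000 nM).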

Compound 4, half-maximal inhibitory concentration: 35700 nM
The estimate for compound 4 lay 1.1-fold (0.03 log units) above the measured number, within the range that was stated.
By their numbers in this assay, from the lowest: compound 3; then compounds 4 and 1 (each within the scatter of the next). At a limit, above all of these: compound 2.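

In this assay, going by these compounds alone, the change from 4-fluorophenyl to phenyl gives an at least 1.1-fold lower number from compound 2 to compound 4 (0.04 log units; that floor lies within the scatter), the first reading that isolates this position, and its floor does not show that the fluoro matters. Compound 2 gives only a limit, so the true size of the step stays unknown: the limit of > 40000 nM in this assay, at which 1 of the 4 values shown sits.

Within the data shown here, compound 4 gives 35700 nM, which provides the first exact starting value for the chloro sulfonamide in this assay.

The compounds shown leave open whether an amine or a carboxylic acid in place of the hydrogen on this phenyl ring would change the number in this assay. They also leave open whether the cyclopropyl group of compound 3, which replaces the whole aryl group, would give a similar step when paired with chloro.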